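One Aryl Swap, Repeated on a Second Core

The source may report more compounds than this note shows. Statements on the series, on what has been measured and on what is new or still open speak of the compounds shown alone.

Four compounds are considered here. Compound 1 `C=C(CC)C(=O)c1ccc(OCc2nc(-c3ccc([N+](=O)[O-])cc3)cs2)c(C)c1C` and compound 2 `C=C(CC)C(=O)c1ccc(OCc2nc(-c3ccc4ccccc4c3)cs2)c(C)c1C` share one core, and compound 3 `C=C(CC)C(=O)c1ccc(OCc2nc(-c3ccc([N+](=O)[O-])cc3)cs2)c(Cl)c1Cl` and compound 4 `C=C(CC)C(=O)c1ccc(OCc2nc(-c3ccc4ccccc4c3)cs2)c(Cl)c1Cl` share another; how the two cores differ from each other is not broken down here.

In a functional assay on HL-60 cells (Homo sapiens) for inhibition, read by trypan blue exclusion, with a stated time of 72 h (a higher number here means a weaker inhibitor of growth, a lower number a stronger inhibitor of growth), compound 1 gives 3600 nM. Compound 2 differs from compound 1 in one place: naphthalen-2-yl in place of 4-nitrophenyl on an aromatic carbon. In this assay compound 2 gives 2000 nM. This change gave a 1.8-fold lower number from compound 1 to compound 2 (0.26 log units; within the scatter), so the two values cannot be told apart with confidence. On the second core, compound 3 gives 1000 nM in this assay. That is the lowest of the three measured numbers, though only compound 1 stands beyond the scatter from compound 3.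

Compound 4 has not been measured. It is related to compound 3 by the same change that leads from compound 1 to compound 2: naphthalen-2-yl in place of 4-nitrophenyl on an aromatic carbon. The surroundings of the exchanged group are the same in both pairs, so the only reference for the size of the step is the earlier pair. The step from compound 3 to compound 4 in this assay is therefore expected to be small, about a 1.7-fold lower number from compound 3 to compound 4 (0.22 log units; within the scatter), resting on the step of a 1.8-fold lower number from compound 1 to compound 2 (0.26 log units; within the scatter) seen between compound 1 and compound 2, which was within the scatter. Compound 4 is estimated to give 600 nM in this assay, plausibly between 250 nM and 1500 nM. A single earlier example is a thin basis, so the range is kept wide.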

Compound 4, concentration for 50% growth inhibition: 3600 nM
Compound 4: middle estimate off by 6.0-fold (0.78 log units), on the low side; measured number outside the range, above it.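

In this assay, among the compounds shown here, placing naphthalen-2-yl where 4-nitrophenyl stood gave a 3.6-fold higher number from compound 3 to compound 4 (0.56 log units; beyond the scatter), so on this core the exchange made the compound a weaker inhibitor of growth, while on the other core the same exchange produced no step that rises above the scatter. Set side by side, the two steps differ, which means that the effect of this change did not carry over from one core to the other in this series, and a step seen on one core was a poor guide to the step on the other: the same change on two cores in this assay, a 1.8-fold lower number (0.26 log units; within the scatter) from compound 1 to compound 2 and a 3.6-fold higher number (0.56 log units; beyond the scatter) from compound 3 to compound 4, 6.5-fold (0.81 log units) apart, beyond the scatter of two such steps This shows only that the outcome of the exchange depends on the core it is made on; with just two pairs, it does not show which feature of the cores is responsible, why the steps part, or whether other aryl exchanges would diverge in the same way.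

The compounds shown leave open how each core would respond to an aryl group carrying an amine or a carboxylic acid in place of the nitro group. They also leave open whether the gap between the two steps would hold for such groups, or would shrink or grow.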